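This account rests on a few compounds, and the source may have more. Where it says the series, first, only, none or still open, it means among the compounds named here.

Compound 3 `C=CCc1cc(C(C)=O)c(O)cc1OCCCCCC#N` gives 41% in an assay on isolated protein for binding affinity to leukotriene B4 receptor 1 (Homo sapiens), tested at 1 uM (a higher number here means more inhibition at the concentration tested (going by the name of the read-out), a lower number less inhibition), and stands second highest of the three numbers measured there. Compound 1 `CCc1cc(C(C)=O)c(O)cc1OCCCCCCC#N` gives 73% in this assay, while compound 2 `COCc1cc(C(C)=O)c(O)cc1OCCCCCCC#N` gives 7%. For the measured compounds named here, compound 1 and compound 3 differ in more than one place, so their values show only that compound 1 sits well above compound 3. Going by the values given here, the one single-point step in the set, a number 66 percentage points lower from compound 1 to compound 2 (beyond the scatter), concerns a methoxy in place of methyl on a saturated chain carbon bound to an aromatic carbon; it is large and downward, but it touches the substituent on the ring, not the chain end.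

Compound 4 `C#CCCCCOc1cc(O)c(C(C)=O)cc1CC=C` carries the change (ethynyl in place of cyanomethyl on a saturated chain carbon, four bonds along the chain from an oxygen on an aromatic ring). Among the compounds with values here, no measured step concerns the terminus of the chain, so the only guidance is that every alteration in this set so far has been answered by a shift in this assay. Within the data shown here, the expected step is a number 11 percentage points lower from compound 3 to compound 4 (beyond the scatter), a moderate drop, since the acceptor at the chain end is removed and no measured pair shows that the number stays level when this position is changed. Compound 4 is therefore estimated at 30%, with a range from 8% to 55%.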

Compound 4, a percentage reported as inhibition, at one concentration (the size of the read-out at that concentration, not a potency): 29%
Beside the measured number, compound 4's estimate is 1 percentage points above it, and the stated range covers the measured number.
By their numbers in this assay, from the lowest: compound 2; then compound 4; then compound 3; then compound 1.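

The chain end now has a measured step of its own: in this assay, ethynyl in place of cyanomethyl on a saturated chain carbon, four bonds along the chain from an oxygen on an aromatic ring, gives a number 12 percentage points lower from compound 3 to compound 4 (beyond the scatter). The position is therefore sensitive to this change, but removing the nitrile, with its one hydrogen-bond acceptor, does not erase the read-out, and compound 4 still gives 29% at the concentration tested. Nothing measured here accounts for the size of this drop.

On these data alone, whether a primary amine or a carboxylic acid at the chain end would raise or lower the number remains open, as does whether this swap gives a similar step with the ring substituent of compound 1 or compound 2. Chain length alone also remains unread: compound 1 and compound 3 differ in more than one place.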